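The compounds below may be only part of what the source reports. "The series", "measured", "known", "first", "only" and "open" are said of these compounds alone.

Measured so far in a functional assay on DLD-1 cells (Homo sapiens) for cytotoxicity, read by resazurin assay, with a stated time of 48 h; a lower number here means that less compound is needed, a higher number that more compound is needed for the effect:

Compound 1, `COc1c(Br)cccc1C(=O)Nc1ccc(Sc2nc3ccccc3s2)c(Cl)c1`: compound 1 gives 10000 nM.
Compound 2, `O=S(=O)(Nc1ccc(-c2nc3cc(NS(=O)(=O)c4ccc(Br)cc4)ccc3o2)cc1)c1ccc(Br)cc1`: compound 2 gives 16000 nM.
Compound 3, `COc1ccc(S(=O)(=O)Nc2ccc3oc(-c4ccc(NC(=O)c5ccc(Cl)s5)cc4)nc3c2)cc1`: compound 3 gives 4600 nM.

Compound 3 has the lowest number of the three, and its gaps to compound 1 and to compound 2 both lie beyond the usual scatter of this assay, so among these three it needs the least compound for the effect. Compound 4, `COc1ccc(S(=O)(=O)Nc2ccc3oc(-c4ccc(NC(=O)C5CCN(C(C)=O)CC5)cc4)nc3c2)cc1`, shares the core of compound 3 and differs from it in one place: 1-acetylpiperidin-4-yl in place of 5-chlorothiophen-2-yl on a carbonyl carbon. No pair of measured compounds isolates a change of this kind, so the size of the step cannot be read from the numbers shown; it can only be judged from the change itself. The step from compound 3 to compound 4 in this assay is expected to be moderate, toward a higher number, beyond the scatter, as a 2.6-fold higher number from compound 3 to compound 4 (0.42 log units; beyond the scatter). On that basis compound 4 is estimated at 12000 nM, with a likely range from 4000 nM to 35000 nM.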

Compound 4, half-maximal effective concentration: 15000 nM
Compound 4: the middle estimate sits 1.3-fold (0.10 log units) below what was measured; measured number inside the range.
By their numbers in this assay, from the lowest: compound 3; then compounds 1, 4 and 2 (each within the scatter of the next).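

Going by these compounds alone, compound 3 and compound 4 form the first pair that differs only in the group on the carbonyl carbon, and replacing 5-chlorothiophen-2-yl with 1-acetylpiperidin-4-yl gives a 3.3-fold higher number from compound 3 to compound 4 (0.51 log units; beyond the scatter) in this assay on the shared core. The step is modest but beyond the scatter, so the group at this place does affect the number, and the chlorinated aromatic ring gives the lower number of the two. No available evidence bears on why the number rises.

The compounds shown leave open whether the chlorine or the ring matters more, which a thiophen-2-yl without chlorine or a phenyl could help separate. They also leave open how a piperidin-4-yl without its acetyl, which carries a free amine, or a carboxylic acid would behave at this place.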